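This account rests on a few compounds, and the source may have more. Where it says the series, first, only, none or still open, it means among the compounds named here.

In a physicochemical assay for lipophilicity, read by HPLC, measured as octanol-water partition (a higher number here means a more lipophilic compound, a lower number a more polar compound), compound 1 `N#Cc1c(-c2ccco2)[n+]([O-])c2ccc(C3OCCO3)cc2[n+]1[O-]` gives 2. Compound 2 `N#Cc1c(-c2ccccc2)[n+]([O-])c2ccc(/C=N/NC(=O)c3ccncc3)cc2[n+]1[O-]` gives 1. For the measured compounds named here, compound 1 has the higher of the two numbers so far, and the gap between them lies beyond the scatter. Compound 3 `Cc1ccc(-c2c(C#N)[n+]([O-])c3cc(C4OCCO4)ccc3[n+]2[O-])cc1` has not yet been measured. It differs from compound 1 in one place, with 4-methylphenyl in place of furan-2-yl on an aromatic carbon. Going by the values given here, no measured pair shows this change, so the expectation rests on the structural change alone. An upward move in this assay beyond the scatter is expected, with an estimated step of a number 1.20 log units higher from compound 1 to compound 3 (beyond the scatter). For compound 3 the expected value is 3.2, with an estimated range of 2.6 to 3.8.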

Compound 3, partition coefficient: 1.6
Compound 3: the middle estimate sits 1.60 log units above what was measured; measured number outside the range, below it.
By their numbers in this assay, from the lowest: compound 2; then compound 3; then compound 1.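

In this assay, for the compounds shown here, the change to 4-methylphenyl from furan-2-yl, on the aromatic carbon next to the ring nitrogen and ortho to a cyano group, gives a number 0.40 log units lower from compound 1 to compound 3 (beyond the scatter) as the first one-place step in the set. At this position, then, the aryl group alone moves the number, and the all-carbon ring with more heavy atoms sits lower than the furan-2-yl ring. Nothing available bears on why the step runs in this direction.

On these data alone, whether an amine or a carboxylic acid on this carbon would move the number further remains open. So does whether this step would hold with a different group in place of the shared acetal ring.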